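Swapping Propyl for Hydroxy on the Urea Analogue

A few compounds are considered here, and "the series" means these few. Any claim that something is new, unique, unknown or untested is made for them only; others in the source may bear on it.

Three compounds were measured in a functional assay on OVCAR-3 cells (Homo sapiens) for inhibition, read by sulforhodamine B assay, with a stated time of 48 h; a lower number here means a stronger inhibitor of growth, a higher number a weaker inhibitor of growth:

Compound 1, `CCOC(=O)C1=C(C)NC(=S)NC1c1ccc(O)cc1`, gives 37.7 ug/mL.
Compound 2, `CCCc1ccc(C2NC(=S)NC(C)=C2C(=O)OCC)cc1`, gives 38.1 ug/mL.
Compound 3, `CCCc1ccc(C2NC(=O)NC(C)=C2C(=O)OCC)cc1`, gives 52.4 ug/mL.

Compound 1 differs from compound 2 by one change, (hydroxy in place of propyl on an aromatic carbon), and this change made the step of a 1.0-fold lower number from compound 2 to compound 1 (0.00 log units; within the scatter). How the core of compound 3 differs from the core of compound 2 is not broken down here; their two values lie within the scatter of each other.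

Compound 4, `CCOC(=O)C1=C(C)NC(=O)NC1c1ccc(O)cc1`, is not yet measured. It differs from compound 3 by hydroxy in place of propyl on an aromatic carbon, the same change as from compound 2 to compound 1, at the same place. Because the earlier step of a 1.0-fold lower number from compound 2 to compound 1 (0.00 log units; within the scatter) was flat, the expected step in this assay is a 1.0-fold lower number from compound 3 to compound 4 (0.00 log units; within the scatter). Compound 4 is therefore estimated at 52 ug/mL, expected to fall between 30 ug/mL and 90 ug/mL.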

Compound 4, concentration for 50% growth inhibition: 27.3 ug/mL
Beside the measured number, compound 4's estimate is 1.9-fold (0.28 log units) above it; measured number outside the range, below it.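

In this assay the swap of propyl for hydroxy on an aromatic carbon gives a small step (a 1.9-fold lower number from compound 3 to compound 4 (0.28 log units; within the scatter)). Set beside the same swap on the other core, this step does not differ from it beyond what repeated measurements would give: the same change on two cores in this assay, a 1.0-fold lower number (0.00 log units; within the scatter) from compound 2 to compound 1 and a 1.9-fold lower number (0.28 log units; within the scatter) from compound 3 to compound 4, 1.9-fold (0.28 log units) apart, within the scatter of two such steps. The swap therefore behaves alike on these two cores, but since both steps lie within the scatter, this shows neither a real effect of the swap on growth inhibition nor that the match would hold on any further core.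

The compounds shown leave open what other groups at this place, such as an amine, a carboxylic acid or a longer chain, would do. They also leave open whether any such group would produce a step large enough to compare clearly between the two cores.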